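Removing one methyl from a highly stable compound

This account rests on a few compounds, and the source may have more. Where it says the series, first, only, none or still open, it means among the compounds named here.

In an ADME assay on microsomes from liver (Mus musculus) for metabolic stability, read by LC-MS, with NADPH named in the record, with a stated time of 60 min, tested at 1 uM, in the absence of a further agent (on this read-out lower numbers stand for a less stable compound and higher numbers for a more stable compound), compound 1 `COc1ccc(-c2c(C)nc3c(N4CC[C@@H](NC(C)=O)C4)ccnn23)cc1OC` gives > 95%, which is a limit of the assay and not an exact number. Compound 2 `COc1ccc(-c2cnc3c(N4CC[C@@H](NC(C)=O)C4)cc(C)nn23)cc1OC` gives > 95%, which is also a limit. It therefore has no exact value, and the only other measured result is a limit too.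

Compound 3 `COc1ccc(-c2cnc3c(N4CC[C@@H](NC(C)=O)C4)ccnn23)cc1OC` differs from compound 2 by one small edit: hydrogen in place of methyl on an aromatic carbon. The 3-acetamidopyrrolidin-1-yl group stays as it is.

Among the compounds with values here, no measured pair shows this change on its own, so any expectation here is tentative. The estimated step of a number at least 3 percentage points lower from compound 2 to compound 3 (that floor lies within the scatter) is slight, downward if anything, and probably within the usual scatter. For compound 3, the expected value is 92%, with an estimated range of 78% to 100%.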

Compound 3, percent of the compound remaining: > 95%
Compound 3 ended at the assay's limit; the forecaster's own chance of this, stated with the estimate: 50%; middle value at least 3 percentage points from the limit.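

No step can be read from compound 1 or compound 2 to compound 3, because all three compounds end at the same limit: the limit of > 95% in this assay, at which 3 of the 3 values shown sit. The compounds shown leave open whether removing either methyl changes metabolic stability at all.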